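Benzyl for 1-phenylethyl on the sulfonyl sulfur

The compounds below may be only part of what the source reports. "The series", "measured", "known", "first", "only" and "open" are said of these compounds alone.

compound 1 `CC(c1ccccc1)S(=O)(=O)NC(=O)C1CCN(c2nc3c(cc2C#N)C(=O)OC3)CC1` gives 4160 nM
compound 2 `N#Cc1cc2c(nc1N1CCC(F)(C(=O)NS(=O)(=O)c3ccc(Cl)s3)CC1)COC2=O` gives 37100 nM
compound 3 `CC(c1ccccc1)S(=O)(=O)NC(=O)C1(F)CCN(c2nc3c(cc2C#N)C(=O)OC3)CC1` gives 9950 nM

In a functional assay (Platelet, plasma) for inhibition, with Homo sapiens as the target (a higher number here means a weaker inhibitor, a lower number a stronger inhibitor), compound 3 stands second highest of the three numbers, with compound 1 lower and compound 2 higher. Compound 4 `N#Cc1cc2c(nc1N1CCC(F)(C(=O)NS(=O)(=O)Cc3ccccc3)CC1)COC2=O` differs from compound 3 by hydrogen in place of methyl on a saturated chain carbon bound to an aromatic carbon and a sulfonyl sulfur so that 1-phenylethyl becomes benzyl. Within the data shown here, no measured step covers this exact change. The nearest evidence is the exchange on the sulfonyl sulfur (a 3.7-fold lower number from compound 2 to compound 3 (0.57 log units; beyond the scatter)) which is modest but replaces a whole group. The fluoro exchange (a 2.4-fold higher number from compound 1 to compound 3 (0.38 log units; beyond the scatter)) is also modest, but it is a different change. Losing one methyl is a smaller edit than the sulfonyl exchange, so a step no larger than modest is expected in this assay and the data set no firm direction. The expected step is a 1.1-fold lower number from compound 3 to compound 4 (0.04 log units; within the scatter) as a working estimate. For compound 4 the estimated value is 9000 nM with an expected range from 3500 nM to 25000 nM in this series.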

Compound 4, half-maximal inhibitory concentration: 1210 nM
Estimate against measurement, compound 4: 7.4-fold (0.87 log units) above, and the stated range ends above it.
By their numbers in this assay, from the lowest: compound 4; then compound 1; then compound 3; then compound 2.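

In this assay, hydrogen in place of methyl on a saturated chain carbon bound to an aromatic carbon and a sulfonyl sulfur gives an 8.2-fold lower number from compound 3 to compound 4 (0.92 log units; beyond the scatter), so a single methyl at this place outweighs the fluoro exchange, which gave a 2.4-fold higher number from compound 1 to compound 3 (0.38 log units; beyond the scatter). Benzyl in place of 5-chlorothiophen-2-yl gives a 31-fold lower number from compound 2 to compound 4 (1.49 log units; beyond the scatter), against a 3.7-fold lower number from compound 2 to compound 3 (0.57 log units; beyond the scatter) for 1-phenylethyl, so the choice of group on the sulfonyl sulfur reaches a large step only once that methyl is gone. No measurement here accounts for the effect of the methyl.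

On these data alone, whether benzyl keeps this gain with hydrogen in place of fluoro on the saturated ring carbon remains open. Also open, as far as these compounds go, is how a longer chain such as 2-phenylethyl, or a plain methyl, on the sulfonyl sulfur would compare in this assay.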